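Acetylation of a Diterpenoid Ester Series and Cell Cytotoxicity

The source may report more compounds than this note shows. Statements on the series, on what has been measured and on what is new or still open speak of the compounds shown alone.

Compound 1 `C=C1[C@H](OC(C)=O)[C@H]2[C@@H](OC(=O)c3ccccc3)[C@@H](C)C[C@]2(OC(C)=O)C(=O)[C@@H](C)/C=C/C(C)(C)C(=O)[C@H](O)[C@H]1OC(C)=O`, compound 2 `C=C1[C@H](OC(C)=O)[C@H]2[C@@H](OC(=O)c3ccccc3)[C@@H](C)C[C@]2(OC(C)=O)C(=O)[C@@H](C)/C=C/C(C)(C)C(=O)[C@H](O)[C@H]1OC(=O)c1ccccc1` and compound 3 `C=C1[C@H](OC(C)=O)[C@H]2[C@@H](OC(=O)c3ccccc3)[C@@H](C)C[C@]2(O)C(=O)[C@@H](C)/C=C/C(C)(C)C(=O)[C@H](O)[C@H]1OC(C)=O` share one core and differ only in their ester groups. In an ADME assay on MCF7 cells (Homo sapiens) for cytotoxicity, read by MTT assay, with a stated time of 48 h (a higher number here means a weaker inhibitor, a lower number a stronger inhibitor), compound 1 gives > 100000 nM, which is a limit of the assay. In this assay compound 2 gives > 100000 nM, also a limit. In this assay compound 3 gives > 100000 nM, again a limit. The change acetyl in place of hydrogen on an oxygen on a saturated carbon made a step that the two limits leave unreadable from compound 3 to compound 1, and the change from compound 1 to compound 2 made a step that the two limits leave unreadable from compound 1 to compound 2. The difference between the cores of compound 2 and compound 3 is not broken down here. Compound 4 `C=C1[C@H](OC(C)=O)[C@H]2[C@@H](OC(=O)c3ccccc3)[C@@H](C)C[C@]2(OC(C)=O)C(=O)[C@@H](C)/C=C/C(C)(C)C(=O)[C@H](OC(C)=O)[C@H]1OC(=O)c1ccccc1` is not yet measured; it arises from compound 2 by acetyl in place of hydrogen on an oxygen on a saturated carbon, the same change as that from compound 3 to compound 1. Because (the limit of > 100000 nM in this assay, at which 3 of the 3 values shown sit), the expected step of a number no higher from compound 2 to compound 4 (the limit leaves the size open) rests on a series that has yet to give a readable number. In this assay compound 4 is estimated at 100000 nM, expected to fall between 30000 nM and 300000 nM.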

Compound 4, half-maximal inhibitory concentration: > 100000 nM
Compound 4: no number, only a limit; the forecaster's own chance of this, stated with the estimate: 85%; the middle value lies on the limit itself.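

In this assay compound 4 gives > 100000 nM and this is a limit; the step between compound 2 and compound 4 cannot be read. The compounds shown leave open whether any of these ester changes alters cytotoxicity: the limit of > 100000 nM in this assay, at which 4 of the 4 values shown sit.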